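Swapping the Aryl Group: From Compound 3 to Compound 4

A few compounds are considered here, and "the series" means these few. Any claim that something is new, unique, unknown or untested is made for them only; others in the source may bear on it.

Measured so far:
Compound 1, `Clc1ccc(Nc2nc(Nc3cn[nH]c3)ncc2Cl)cc1`: in a functional assay on MCF7 cells (Homo sapiens) for antiproliferative activity, read by MTT assay, with a stated time of 48 h (on this read-out higher numbers stand for weaker inhibition and lower numbers for stronger inhibition), compound 1 gives 1930 nM.
Compound 2, `Clc1cnc(Nc2cn[nH]c2)nc1Nc1ccccc1`: in this assay compound 2 gives 3660 nM.
Compound 3, `Fc1ccc(Nc2nc(Nc3cn[nH]c3)ncc2Cl)cc1`: in this assay compound 3 gives 1870 nM.

Compound 3 carries the lowest of the three numbers, yet its separation from compound 1 (a 1.0-fold lower number from compound 1 to compound 3 (0.01 log units; within the scatter)) and from compound 2 (a 2.0-fold lower number from compound 2 to compound 3 (0.29 log units; within the scatter)) stays within the scatter, so no order among the three can be claimed. Compound 4, `Clc1ccccc1Nc1nc(Nc2cn[nH]c2)ncc1Cl`, differs from compound 3 as follows: 2-chlorophenyl in place of 4-fluorophenyl on a nitrogen on an aromatic ring.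

All three measured steps alter only the substitution on this aryl group: a 1.9-fold higher number from compound 1 to compound 2 (0.28 log units; within the scatter), a 1.0-fold lower number from compound 1 to compound 3 (0.01 log units; within the scatter) and a 2.0-fold lower number from compound 2 to compound 3 (0.29 log units; within the scatter), none beyond the scatter. On that basis no step beyond the scatter is expected for compound 4, and its step from compound 3 is estimated as a 1.3-fold higher number from compound 3 to compound 4 (0.13 log units; within the scatter). Compound 4 is therefore expected to give about 2500 nM, within a range of 1000 nM to 6500 nM.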

Compound 4, half-maximal inhibitory concentration: 1100 nM
For compound 4 the middle estimate is 2.3-fold (0.36 log units) above the measured one, and the stated range covers the measured number.
By their numbers in this assay, from the lowest: compounds 4, 3, 1 and 2 (each within the scatter of the next, the first and the last beyond it).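

Replacing hydrogen with chloro on the aryl group now gives a step beyond the scatter in this assay, though a modest one: a 3.3-fold lower number from compound 2 to compound 4 (0.52 log units; beyond the scatter). Against the halogenated aryl groups, 2-chlorophenyl stays within the scatter, with a 1.8-fold lower number from compound 1 to compound 4 (0.24 log units; within the scatter) and a 1.7-fold lower number from compound 3 to compound 4 (0.23 log units; within the scatter), so moving the chloro or exchanging it for fluoro cannot be ranked here. No evidence is available to explain these results. As far as these compounds go, it remains open how a methoxy group or an amine on this phenyl ring would compare with chloro, and whether a second chloro would move the number further.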